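This account rests on a few compounds, and the source may have more. Where it says the series, first, only, none or still open, it means among the compounds named here.

Measured so far:

- compound 1, `CCCCCCCC/C=C\CCCCCCCC(=O)OC[C@H](C)OP(=O)(O)OC[C@H](N)C(=O)O`: 11.2%
- compound 2, `CCCCCCCC/C=C\CCCCCCCC(=O)O[C@H](C)COP(=O)(O)OC[C@H](N)C(=O)O`: 6.1%

Both numbers come from an assay on HEK293 cells for agonist activity at probable G-protein coupled receptor 34 (Mus musculus), with a stated time of 1 h; on this read-out higher numbers stand for larger maximal responses and lower numbers for smaller maximal responses. On this read-out compound 1 gives 11.2%, which is the higher of the two values recorded. Compound 2 gives 6.1%; the gap between compound 1 and compound 2 lies within the usual scatter of repeated measurements, so no order between the two can be stated. Neither value is far from the bottom of the scale.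

Compound 3, `CCCCCCCC/C=C\CCCCCCCC(=O)OC[C@H](COC)OP(=O)(O)OC[C@H](N)C(=O)O`, has not been measured. It differs from compound 1 in one place only: methoxy in place of hydrogen on a saturated chain carbon, two bonds along the chain from an oxygen on an unsaturated carbon. No pair of measured compounds that differ in a single place is available, so the size of this kind of step cannot be read from the data shown.

In this assay compound 3 is expected to stay close to compound 1, with an estimated step from compound 1 to compound 3 of a number 0.8 percentage points higher from compound 1 to compound 3 (within the scatter), that is, no change beyond the scatter in either direction. The estimated value for compound 3 is 12%, with a range from 2% to 28%.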

Compound 3, largest response reached (Emax), in percent of the reference or control that the assay uses: 7.5%
Compound 3: the middle estimate sits 4.5 percentage points above what was measured; the range from low to high includes it.
By their numbers in this assay, from the lowest: compounds 2, 3 and 1 (each within the scatter of the next).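

In this assay, going by these compounds alone, methoxy in place of hydrogen on a saturated chain carbon, two bonds along the chain from an oxygen on an unsaturated carbon, gives the first single-place step, a number 3.7 percentage points lower from compound 1 to compound 3 (within the scatter), so the size of this kind of change can now be read for one pair. Cut one bond further out, the same difference reads methyl to methoxymethyl, and at this position that change leaves the maximal response of compound 3 indistinguishable from that of compound 1, with no shift beyond the scatter in either direction. No supporting measurement bears on why the step has this size.

On these data alone, what remains open is whether another group at this same carbon, such as an amine, a carboxylic acid or a longer chain such as butoxy, would move the maximal response beyond the scatter in this assay. As far as these compounds go, it is also open whether methoxy at the corresponding place on the core of compound 2 would give a step of similar size, since this reading rests on a single pair.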